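Sulfonamide tail variations: solubility working notes

The compounds below may be only part of what the source reports. "The series", "measured", "known", "first", "only" and "open" are said of these compounds alone.

compound 1 `Cc1ncc([N+](=O)[O-])n1CCS(=O)(=O)NCCN(C)C`: 46800000 nM
compound 2 `Cc1ncc([N+](=O)[O-])n1CCS(=O)(=O)NCCCN(C)C`: > 53800000 nM

In a physicochemical assay for solubility, read by HPLC (a higher number here means a more soluble compound, a lower number a less soluble compound), compound 1 gives 46800000 nM. For compound 2 the figure > 53800000 nM is a limit of the assay, not a number (the limit of > 53800000 nM in this assay, at which 1 of the 2 values shown sits). Compound 2 therefore stands at the ceiling of what this assay reports. The step of an at least 1.1-fold higher number from compound 1 to compound 2 (0.06 log units; that floor lies within the scatter) stays within the scatter. Compound 3 `Cc1ncc([N+](=O)[O-])n1CCS(=O)(=O)N1CCOCC1` differs from compound 2 by morpholin-4-yl in place of (3-(dimethylamino)propyl)amino on a sulfonyl sulfur. Within the data shown here, no measured step covers this exchange; the only step seen, an at least 1.1-fold higher number from compound 1 to compound 2 (0.06 log units; that floor lies within the scatter), alters the chain alone, so the measured steps offer no direction beyond the scatter. Compound 3 is nevertheless estimated at 15000000 nM, range 3000000 nM to 53800000 nM. That estimate implies an expected step of an at least 3.5-fold lower number from compound 2 to compound 3 (0.55 log units; beyond the scatter).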

Compound 3, solubility: 2770000 nM
For compound 3 the middle estimate is 5.4-fold (0.73 log units) above the measured one; the whole stated range lies above it.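

In this assay, the group on the sulfonyl sulfur matters far more than the chain length change did: a 17-fold lower number from compound 1 to compound 3 (1.23 log units; beyond the scatter) for morpholin-4-yl in place of (2-(dimethylamino)ethyl)amino. The exchange from the longer tail gives an at least 19-fold lower number from compound 2 to compound 3 (1.28 log units; beyond the scatter). Compound 2 carries a limit of the assay, not a number, so that step is only a floor: the limit of > 53800000 nM in this assay, at which 1 of the 3 values shown sits.

Still open, from the compounds shown here alone, is whether a piperazine ring on the sulfonyl sulfur, or a chain ending in a hydroxyl group, would stay close to compound 1 or fall towards compound 3.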